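Swapping the dichloropyridine amide for a plain pyridine

The compounds below may be only part of what the source reports. "The series", "measured", "known", "first", "only" and "open" are said of these compounds alone.

Measured compounds:
- Compound 1, `COc1ccc(-c2ccc(Cl)cc2)c2cc(C(=O)Nc3ccc(Cn4ccnc4)cc3)oc12`: "not determined" (no result reported)
- Compound 2, `COc1ccc(-c2ccccc2)c2cc(C(=O)Nc3c(Cl)cncc3Cl)oc12`: 74%
- Compound 3, `COC(=O)c1ccc(OC)c2oc(C(=O)Nc3ccc(OC)cc3)cc12`: "not determined" (no result reported)

Only compound 2 carries a number. In a functional assay on the whole organism for inhibition, with Mus musculus as the target, at a dose of 10 mg/kg by the oral route (a lower number here means less inhibition, a higher number more inhibition at the dose given (going by the name of the read-out)), compound 2 gives 74%, a clear majority of the response blocked at the dose used. Compounds 1 and 3 share the same style of core with an amide attached, but for neither of them was a result reported, so compound 2 stands alone as the single point of reference.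

Compound 4, `COc1ccc(-c2ccccc2)c2cc(C(=O)Nc3ccncc3)oc12`, keeps everything of compound 2 except the group on the amide nitrogen. The change is pyridin-4-yl in place of 3,5-dichloropyridin-4-yl on an amide-type nitrogen. Two chlorine atoms leave and nothing takes their place on the ring.

Going by the values given here, no step between two measured compounds exists here, so the size of the effect can only be guessed. Stripping both chlorines is a substantial edit to the amide side, and the expected step of a number 29 percentage points lower from compound 2 to compound 4 (beyond the scatter) in this assay is a drop beyond the usual scatter, not a gain. Compound 4 is therefore estimated to give 45% in this assay. The range for compound 4 is expected to run from 15% to 75%.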

Compound 4, a percentage reported as inhibition, in the whole organism at one dose (the size of the read-out at that dose, not a potency): 40%
For compound 4 the middle estimate is 5 percentage points above the measured one; low and high end bracket the measured number.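

In this assay, going by these compounds alone, removing both chlorine atoms from the group on the amide nitrogen gives a number 34 percentage points lower from compound 2 to compound 4 (beyond the scatter) and this is the first measured step in the set. It shows that the effect at the dose given responds to a change at this position, which a single value could not show. Even so, the plain pyridin-4-yl group does not abolish the effect, as compound 4 still gives 40% in this assay and nothing measured here explains the size of the step.

On these data alone, both chlorine atoms leave together, so their separate shares remain open, and a pyridine ring keeping a single chlorine atom would help to tell them apart. As far as these compounds go, it is also open whether chlorine itself counts or whether fluorine atoms or methyl groups in its place would give a similar result.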